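Aryl variation on the shared core: difluorophenyl step

This account rests on a few compounds, and the source may have more. Where it says the series, first, only, none or still open, it means among the compounds named here.

In a functional assay on cardiac atrium for agonist activity at histamine H2 receptor (Cavia porcellus) (on this read-out higher numbers stand for higher potency (the scale is a negative logarithm) and lower numbers for lower potency), compound 2 `N=C(NCCCc1c[nH]cn1)NCCC(c1ccccn1)c1ccccc1F` gives 7.46 and stands at the lower of the two recorded numbers, though the gap to compound 1 is within the scatter. Compound 1 `N=C(NCCCc1c[nH]cn1)NCCC(c1ccc(C(F)(F)F)cc1)c1ccccn1` gives 7.76 in this assay. Compound 3 `N=C(NCCCc1c[nH]cn1)NCCC(c1cc(F)cc(F)c1)c1ccccn1` differs from compound 2 by 3,5-difluorophenyl in place of 2-fluorophenyl on a saturated chain carbon bound to an aromatic carbon and a saturated chain carbon. Going by the values given here, the only measured step that bears on this aryl swap, a number 0.30 log units lower from compound 1 to compound 2 (within the scatter), was within the scatter, so the expected step in this assay is none beyond the scatter, estimated as a number 0.14 log units higher from compound 2 to compound 3 (within the scatter). Compound 3 is therefore expected at 7.6, with a range of 7.1 to 8.1.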

Compound 3, negative logarithm of the half-maximal effective concentration: 8.05
For compound 3 the middle estimate is 0.45 log units below the measured one, and the stated range covers the measured number.
By their numbers in this assay, from the lowest: compounds 2, 1 and 3 (each within the scatter of the next, the first and the last beyond it).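

In this assay, going by these compounds alone, the entry of 3,5-difluorophenyl at this saturated chain carbon gives a number 0.59 log units higher from compound 2 to compound 3 (beyond the scatter) and so the first step beyond the scatter. Set against 4-(trifluoromethyl)phenyl, the same group gives a number 0.29 log units higher from compound 1 to compound 3 (within the scatter) and no separation, so only the pair of 2-fluorophenyl and 3,5-difluorophenyl is resolved at this place. Nothing measured on these compounds accounts for the step. Going by these compounds, whether the gain follows the number of fluorines or where they sit stays open, since these compounds cannot separate the two. Also open, on these data alone, is how a methoxy, a nitrile or an amine on the phenyl ring would read here.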